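This account rests on a few compounds, and the source may have more. Where it says the series, first, only, none or still open, it means among the compounds named here.

In a functional assay on MCF7 cells (Homo sapiens) for inhibition, read by CCK-8 assay, with a stated time of 72 h (a lower number here means a stronger inhibitor, a higher number a weaker inhibitor), compound 1 `O=C(/C=C/c1cccnc1)NCCCCCCc1cccc(S(=O)(=O)Nc2ccccc2)c1` gives 0.63 nM. In this assay compound 2 `O=C(/C=C/c1cccnc1)NCCCCCCc1cccc(S(=O)(=O)Nc2ccc(Cl)cc2)c1` gives 5.94 nM. In this assay compound 3 `O=C(/C=C/c1cccnc1)NCCCCCCc1cccc(S(=O)(=O)Nc2ccc(F)cc2)c1` gives 0.91 nM.

The change from compound 1 to compound 2 is chloro in place of hydrogen on an aromatic carbon, and it produced a 9.4-fold higher number from compound 1 to compound 2 (0.97 log units; beyond the scatter). Compound 3 differs from compound 1 by fluoro in place of hydrogen on an aromatic carbon, with a 1.4-fold higher number from compound 1 to compound 3 (0.16 log units; within the scatter); this is also how the core of compound 3 differs from the core of compound 1. Between compound 2 and compound 3 there is a 6.5-fold lower number from compound 2 to compound 3 (0.81 log units; beyond the scatter).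

Compound 4 `O=C(/C=C/c1cccnc1)NCCCCCCc1cccc(S(=O)(=O)Nc2ccc(F)c(Cl)c2)c1` has not been measured. It differs from compound 3 by chloro in place of hydrogen on an aromatic carbon. This is the same kind of change as from compound 1 to compound 2, but not the same: in compound 2 the chloro sits para to a large group, whereas in compound 4 it sits ortho to a fluoro group and meta to a large group. A rise in the number is expected for compound 4, probably somewhat smaller than the earlier one because the earlier step was a 9.4-fold higher number from compound 1 to compound 2 (0.97 log units; beyond the scatter) at a different place; the expected step is a 4.4-fold higher number from compound 3 to compound 4 (0.64 log units; beyond the scatter). Compound 4 is estimated at 4 nM, expected to lie between 1.2 nM and 15 nM.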

Compound 4, half-maximal inhibitory concentration: 6.3 nM
Compound 4: middle estimate off by 1.6-fold (0.20 log units), on the low side, within the range that was stated.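

In this assay, chloro in place of hydrogen gives a 6.9-fold higher number from compound 3 to compound 4 (0.84 log units; beyond the scatter), and this step agrees in size with the one seen on the core of compound 1: the same change on two cores in this assay, a 9.4-fold higher number (0.97 log units; beyond the scatter) from compound 1 to compound 2 and a 6.9-fold higher number (0.84 log units; beyond the scatter) from compound 3 to compound 4, 1.4-fold (0.13 log units) apart, within the scatter of two such steps With 3-chloro-4-fluorophenyl in place of 4-chlorophenyl there is a 1.1-fold higher number from compound 2 to compound 4 (0.03 log units; within the scatter), and with it in place of phenyl there is a 10-fold higher number from compound 1 to compound 4 (1.00 log units; beyond the scatter). The chloro step therefore carried over between these two closely related cores, but this is a single pair of steps with the chloro at a different place in each, so it does not show that the step would hold on cores that differ more.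

The compounds shown leave open what a 3-chlorophenyl group without the fluoro would give, which would separate the effect of the place of the chloro from that of the fluoro. Also open, on these data alone, is whether bromo, methyl or methoxy in place of the chloro, or a longer chain in the shared core, would give a step of similar size.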